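Methyl on the amide nitrogen of compound 2

The compounds below may be only part of what the source reports. "The series", "measured", "known", "first", "only" and "open" are said of these compounds alone.

Measured in a functional assay on KG-1 cells (Homo sapiens) for cytotoxicity, read by luminescence and CellTiter-Glo, with a stated time of 3 days; a lower number here means a stronger inhibitor, a higher number a weaker inhibitor:
- compound 1 `N#Cc1ccc(NC(=O)c2cc(-c3ccccc3)ccc2O)cc1`: 1300 nM
- compound 2 `N#Cc1ccc(NC(=O)c2cc(F)ccc2O)cc1`: 2670 nM

Compound 2 holds the higher of the two numbers. The gap is modest: a 2.1-fold higher number from compound 1 to compound 2 (0.31 log units; beyond the scatter). Compound 3 `CN(C(=O)c1cc(F)ccc1O)c1ccc(C#N)cc1` brings one change, (methyl in place of hydrogen on an amide-type nitrogen), methyl in place of hydrogen on an amide-type nitrogen. Within the data shown here, the only measured step, fluoro in place of phenyl on an aromatic carbon, does not touch that nitrogen, so it gives little guidance here. A moderately higher number in this assay is nevertheless expected, with wide uncertainty. The expected step is a 2.6-fold higher number from compound 2 to compound 3 (0.42 log units; beyond the scatter). Compound 3 is estimated at 7000 nM, with an expected range of 2500 nM to 20000 nM.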

Compound 3, half-maximal inhibitory concentration: > 10000 nM
Compound 3 gave a limit, no number; the forecaster's own chance of this, stated with the estimate: 20%; middle value at least 1.4-fold (0.15 log units) from the limit.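

Compound 3 gives the first view of the amide nitrogen, as the earlier step changed only a group on an aromatic carbon. In this assay, methyl in place of hydrogen on this nitrogen gives an at least 3.7-fold higher number from compound 2 to compound 3 (0.57 log units; beyond the scatter), so the position does not tolerate this small change without a weaker result. The true size of that step stays unknown, since the value for compound 3 is a limit and not a number: the limit of > 10000 nM in this assay, at which 1 of the 3 values shown sits.

The compounds shown cannot separate the loss of the amide hydrogen from the presence of the methyl. From the compounds shown here alone, whether an ethyl or a longer chain on this nitrogen would behave the same way also stays open.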